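This account rests on a few compounds, and the source may have more. Where it says the series, first, only, none or still open, it means among the compounds named here.

Measured so far:
compound 1, `NN1C(=O)/C(=C/c2c[nH]c3ccccc23)SC1=S`; compound 2, `O=C1NC(=O)/C(=C/c2c[nH]c3ccccc23)S1`; compound 3, `O=C1NC(=S)S/C1=C\c1c[nH]c2ccc(Br)cc12`.

In a functional assay on T47D cells (Homo sapiens) for cytotoxicity, read by MTT assay, with a stated time of 72 h (a lower number here means a stronger inhibitor, a higher number a weaker inhibitor), compound 1 gives only a limit, > 50000 nM. Compound 2 gives 1930 nM, the lowest of the two numbers. Compound 3 gives 11700 nM, a higher number, and the gap between compound 2 and compound 3 lies beyond the usual scatter. Compound 4, `O=C1NC(=O)/C(=C/c2c[nH]c3ccc(Br)cc23)S1`, differs from compound 2 by bromo in place of hydrogen on an aromatic carbon. Going by the values given here, no pair of measured compounds differs in this one place alone, so nothing measured shows the size of such a step here. The step from compound 2 to compound 4 is expected to be small, a 1.0-fold higher number from compound 2 to compound 4 (0.02 log units; within the scatter), in either direction and probably within the scatter. Compound 4 is therefore estimated at 2000 nM, between 700 nM and 6000 nM.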

Compound 4, half-maximal inhibitory concentration: > 50000 nM
Compound 4 was reported as a limit (the forecaster's own chance of this, stated with the estimate: 3%); middle value at least 25-fold (1.39 log units) away from the limit.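

In this assay, bromo in place of hydrogen on this aromatic carbon is no minor change on the core of compound 2: it gives an at least 25-fold higher number from compound 2 to compound 4 (1.41 log units; beyond the scatter). At this position, then, a single added bromine atom is enough to lose nearly all measurable activity in this pair. Compound 4 gives a limit, not a number, so the full size of the step stays unknown: the limit of > 50000 nM in this assay, at which 2 of the 4 values shown sit.

Going by these compounds, whether fluoro, a methoxy group or an amine on this carbon would keep the activity of compound 2 remains open. So does whether bromo on another carbon of this ring would give the same result.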